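Removing an ortho ester from the benzoate of compound 3

The source may hold more compounds than are shown below. What is called first, only, known or untested is meant among the compounds shown, and "the series" means these compounds.

Of the compounds shown here, three sharing one core have been measured in a functional assay on NFS-60 cells (Mus musculus) for inhibition, read by MTT assay, with a stated time of 72 h; a higher number here means a weaker inhibitor, a lower number a stronger inhibitor. Compound 1 `O=C(OC1(C(=O)Nc2ccc([N+](=O)[O-])cc2)CCCCC1)c1ccc(C(F)(F)F)cc1` gives 26 nM, compound 2 `O=C(OC1(C(=O)Nc2ccc([N+](=O)[O-])cc2)CCCCC1)c1ccc([N+](=O)[O-])cc1` gives 7.7 nM, and compound 3 `CCOC(=O)c1ccccc1C(=O)OC1(C(=O)Nc2ccc([N+](=O)[O-])cc2)CCCCC1` gives 488 nM. Compound 3 therefore has the highest of the three numbers and is the weakest inhibitor of the set, with compound 1 nearest to it and compound 2 furthest away.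

Compound 4 `O=C(OC1(C(=O)Nc2ccc([N+](=O)[O-])cc2)CCCCC1)c1ccccc1` has not yet been measured. It differs from compound 3 in one place: hydrogen in place of ethoxycarbonyl on an aromatic carbon. Going by the values given here, the only measured step, a 3.4-fold lower number from compound 1 to compound 2 (0.53 log units; beyond the scatter), swaps one group for another on the far side of the same aromatic ring and so does not speak directly to the change at hand. What the values do show is that compound 1 and compound 2, which carry nothing beside the ester link, both sit far below compound 3. On that basis the step of an 8.1-fold lower number from compound 3 to compound 4 (0.91 log units; beyond the scatter) is expected to bring a clearly lower number in this assay, though where compound 4 lands between the two ends is uncertain. The estimate for compound 4 is 60 nM, with a range from 15 nM to 250 nM.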

Compound 4, half-maximal inhibitory concentration: 766 nM
Estimate against measurement, compound 4: 13-fold (1.11 log units) below; measured number above the stated range.
By their numbers in this assay, from the lowest: compound 2; then compound 1; then compounds 3 and 4 (each within the scatter of the next).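

In this assay, taking the ethoxycarbonyl off the aromatic ring makes no measurable difference: a 1.6-fold higher number from compound 3 to compound 4 (0.20 log units; within the scatter) is a step too small to separate the two compounds, so the high number of compound 3 cannot be pinned on that group alone. The same compound 4 shows that a bare benzoate is not enough for a low number, since hydrogen in place of nitro gives a 99-fold higher number from compound 2 to compound 4 (2.00 log units; beyond the scatter) and hydrogen in place of trifluoromethyl gives a 29-fold higher number from compound 1 to compound 4 (1.47 log units; beyond the scatter), both large steps that tie the low numbers of compound 1 and compound 2 to the group each carries. Nothing shown here accounts for these steps or for the difference between them.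

The compounds shown leave open whether an amine or a carboxylic acid on the aromatic carbon that holds the nitro in compound 2 would also give a low number, or whether only some groups do so there. They also leave open what a nitro would do in the place of the ethoxycarbonyl, ortho to a large group.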